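This account rests on a few compounds, and the source may have more. Where it says the series, first, only, none or still open, it means among the compounds named here.

The series shares one core and differs only in the aryl group on the carbonyl carbon. Compound 1 `COc1ccc(/C=C/c2cc(OC)cc(OC)c2/C=C/C(=O)c2cccc(OC)c2)cc1` gives 4.3 ug/mL in a functional assay on B16-F10 cells (Mus musculus) for antiproliferative activity, read by MTT assay, with a stated time of 48 h; a lower number here means a stronger inhibitor, a higher number a weaker inhibitor; compound 2 `CCCCOc1ccc(C(=O)/C=C/c2c(/C=C/c3ccc(OC)cc3)cc(OC)cc2OC)cc1` gives 5.3 ug/mL there; compound 3 `COc1ccc(/C=C/c2cc(OC)cc(OC)c2/C=C/C(=O)c2ccc(N)cc2)cc1` gives 2.8 ug/mL, the lowest of the three numbers, though its gaps to compound 1 and compound 2 both lie within the scatter. Compound 4 `COc1ccc(/C=C/c2cc(OC)cc(OC)c2/C=C/C(=O)c2ccc(C)cc2C)cc1` is not yet measured. The change from compound 3 to compound 4 is 2,4-dimethylphenyl in place of 4-aminophenyl on a carbonyl carbon. Going by the values given here, three measured steps bear on it, each an exchange of the aryl group on the carbonyl carbon: a 1.2-fold higher number from compound 1 to compound 2 (0.09 log units; within the scatter), a 1.5-fold lower number from compound 1 to compound 3 (0.19 log units; within the scatter), and a 1.9-fold lower number from compound 2 to compound 3 (0.28 log units; within the scatter). None of them moves beyond the scatter, so the account expects that the step from compound 3 to compound 4 will also stay within it, with a 1.4-fold higher number from compound 3 to compound 4 (0.15 log units; within the scatter) estimated as the likely outcome. Compound 4 is therefore expected to give about 4 ug/mL, within a range of 2 ug/mL to 8 ug/mL.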

Compound 4, half-maximal inhibitory concentration: 4 ug/mL
For compound 4 middle estimate and measured number coincide at the digits printed, within the range that was stated.
By their numbers in this assay, from the lowest: compounds 3, 4, 1 and 2 (each within the scatter of the next).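

At the aryl group on the carbonyl carbon, 2,4-dimethylphenyl takes its place among the earlier groups in this assay, since its exchange for 4-aminophenyl (a 1.4-fold higher number from compound 3 to compound 4 (0.15 log units; within the scatter)), for 4-butoxyphenyl (a 1.3-fold lower number from compound 2 to compound 4 (0.12 log units; within the scatter)) and for 3-methoxyphenyl (a 1.1-fold lower number from compound 1 to compound 4 (0.03 log units; within the scatter)) stays within the scatter each time. The earlier aryl groups each carried one substituent joined through nitrogen or oxygen, whereas this one carries two methyl groups and has no hydrogen-bond donor or acceptor, so this position has now kept its number across a change of that kind as well. No measurement available here explains why these numbers stay so close.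

From the compounds shown here alone, all four aryl groups leave the numbers within the scatter of one another, so it remains open whether any group at this position can move the number beyond it. A carboxylic acid or a chlorine on the aryl ring, or a saturated carbon chain in place of the ring, would test that.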